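The source may report more compounds than this note shows. Statements on the series, on what has been measured and on what is new or still open speak of the compounds shown alone.

Compound 1 `COC1CN(C(=O)/C=C/c2ccncc2-c2ccc3ccccc3c2)C1` is tested in an assay on a protein complex for inhibition of CDK8/Cyclin C (Homo sapiens), with a stated time of 1 h, tested at 10 uM (on this read-out higher numbers stand for more inhibition at the one concentration tested (going by the name of the read-out) and lower numbers for less inhibition), where compound 1 gives 100%. That is the highest of the three numbers shown, though compound 2 `CNC(=O)/C=C/c1ccncc1-c1ccc2c(cnn2C)c1` comes close: in this assay compound 2 gives 98%, within the usual scatter of the first. Compound 3 `NC(=O)/C=C/c1ccncc1Nc1ccc(F)cc1` sits further off; in this assay compound 3 gives 70%, a gap beyond the scatter. Compound 4 `O=C(/C=C/c1ccncc1-c1ccc2ccccc2c1)N1CCOCC1` is not yet measured. It differs from compound 1 by morpholin-4-yl in place of 3-methoxyazetidin-1-yl on a carbonyl carbon, the same atoms joined differently. No step between two measured compounds of this kind is shown, so the direction is open. Because compound 1 already gives 100%, the expected step of a number 5 percentage points lower from compound 1 to compound 4 (within the scatter) is small and within the scatter. Compound 4 is expected to give 95%, ranging from 80% to 100%.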

Compound 4, a percentage reported as inhibition, at one concentration (the size of the read-out at that concentration, not a potency): 99%
The estimate for compound 4 lay 4 percentage points below the measured number, and the stated range covers the measured number.
By their numbers in this assay, from the lowest: compound 3; then compounds 2, 4 and 1 (each within the scatter of the next).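

Putting morpholin-4-yl in place of 3-methoxyazetidin-1-yl on a carbonyl carbon gives, in this assay, a number 1 percentage points lower from compound 1 to compound 4 (within the scatter), so the six-membered and four-membered rings cannot be told apart at this position. Both compounds sit close to the top of the scale at a single concentration, so a real difference in potency could stay hidden. Nothing measured here offers an explanation for this result. Still open, as far as these compounds go, is how the read-out responds to a different kind of group on this carbonyl carbon, such as piperazin-1-yl or a longer chain ending in a carboxylic acid.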